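The source may report more compounds than this note shows. Statements on the series, on what has been measured and on what is new or still open speak of the compounds shown alone.

In an ADME assay on microsomes from liver (Homo sapiens) for metabolic stability, read by LC-MS, with a stated time of 10 min (a lower number here means that less of the compound is left, a higher number that more of the compound is left), three compounds with a shared core have been measured, and they differ only in the group on an amine nitrogen in a ring. Compound 3 `CN1CCN(c2cccc3c2C[C@H](CN(C)[C@H]2CCCc4cccnc42)NC3)CC1`, which carries methyl there, gives 75.8%. Compound 1 `CN(C[C@H]1Cc2c(cccc2N2CCN(C3COC3)CC2)CN1)[C@H]1CCCc2cccnc21`, which carries oxetan-3-yl, gives 83.1%, and the comparison is a number 7.3 percentage points lower from compound 1 to compound 3 (within the scatter), so these two cannot be told apart. Compound 2 `CC(C)N1CCN(c2cccc3c2C[C@H](CN(C)[C@H]2CCCc4cccnc42)NC3)CC1`, which carries isopropyl, gives 56.6%, clearly apart from both, with a number 26.5 percentage points lower from compound 1 to compound 2 (beyond the scatter) and a number 19.2 percentage points higher from compound 2 to compound 3 (beyond the scatter).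

Compound 4 `CN(C[C@H]1Cc2c(cccc2N2CCN(c3ncccn3)CC2)CN1)[C@H]1CCCc2cccnc21` changes the same place, with pyrimidin-2-yl in place of methyl on an amine nitrogen in a ring. Among the compounds with values here, no measured compound has an aromatic ring on this nitrogen, so the three steps offer only indirect guidance. Compound 2 shows that a change here can matter, through a number 19.2 percentage points higher from compound 2 to compound 3 (beyond the scatter), while compound 1 shows that a group other than methyl can leave the number unmoved, through a number 7.3 percentage points lower from compound 1 to compound 3 (within the scatter). A modest fall seems more likely than a rise, and the expected step is a number 12.8 percentage points lower from compound 3 to compound 4 (beyond the scatter), though the uncertainty is wide. For compound 4, the estimated value is 63%, with an expected range of 40% to 83%.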

Compound 4, percent of the compound remaining: 35.5%
Estimate against measurement, compound 4: 27.5 percentage points above; measured number outside the range, below it.
By their numbers in this assay, from the lowest: compound 4; then compound 2; then compounds 3 and 1 (each within the scatter of the next).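

In this assay, within the data shown here, the group on this amine nitrogen turns out to matter far more than the earlier compounds could show: bringing in pyrimidin-2-yl, the only aromatic ring at this place among the four compounds, gives a number 40.3 percentage points lower from compound 3 to compound 4 (beyond the scatter) and counts as a large step. The fall is not tied to methyl as the starting point, since the other two groups give the same direction, a number 21.1 percentage points lower from compound 2 to compound 4 (beyond the scatter) and a number 47.6 percentage points lower from compound 1 to compound 4 (beyond the scatter) in turn, which leaves compound 4 with the lowest number of the series, under even the isopropyl compound that had been the lowest so far. Nothing available here gives a measured reason for this fall.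

With only one aromatic group at this place, the compounds shown cannot separate the effect of an aromatic ring as such from that of the two ring nitrogens in pyrimidin-2-yl, and a plain phenyl group on the same nitrogen would address that question. From the compounds shown here alone, it also stays open how a carbonyl-linked group such as acetyl would behave here, since every group so far joins this nitrogen through a carbon with no carbonyl.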